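Cyanophenyl change on the ethylpiperazine compound

The source may hold more compounds than are shown below. What is called first, only, known or untested is meant among the compounds shown, and "the series" means these compounds.

Measured so far in a functional assay on A549 cells (Homo sapiens) for antiproliferative activity, read by MTT assay, with a stated time of 72 h; on this read-out higher numbers stand for weaker inhibition and lower numbers for stronger inhibition:
- compound 1 (`COc1cc2c(Nc3ccc(C#N)cc3)ncnc2cc1OCCCN(C)Cc1ccccc1`) gives > 100000 nM as a limit of the assay
- compound 2 (`CCN1CCN(CCCOc2cc3ncnc(Nc4ccc(C#N)cc4)c3cc2OC)CC1`) gives 16000 nM as a true number

Going by the values given here, compound 2 holds the only true number (16000 nM). Among the compounds with values here, the only other reading, that of compound 1, is a limit. Compound 3 (`CCN1CCN(CCCOc2cc3ncnc(Nc4cccc(C#N)c4)c3cc2OC)CC1`) has 3-cyanophenyl in place of 4-cyanophenyl on a nitrogen on an aromatic ring. Within the data shown here, the one measured step, an at least 6.2-fold lower number from compound 1 to compound 2 (0.79 log units; beyond the scatter), exchanged benzyl(methyl)amino for 4-ethylpiperazin-1-yl on the chain and left the cyanophenyl group untouched. That step therefore gives no size for the present change, and no step beyond the scatter is expected in this assay in either direction. The expected change is a 1.1-fold lower number from compound 2 to compound 3 (0.06 log units; within the scatter) in this estimate. Compound 3 is expected at 14000 nM within an estimated range of 5000 nM to 45000 nM on this read-out.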

Compound 3, half-maximal inhibitory concentration: 18700 nM
For compound 3 the middle estimate is 1.3-fold (0.13 log units) below the measured one, and the stated range covers the measured number.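

In this assay, the exchange of 4-cyanophenyl for 3-cyanophenyl on a nitrogen on an aromatic ring gives a 1.2-fold higher number from compound 2 to compound 3 (0.07 log units; within the scatter). The earlier pair differed only at the chain end and gave no information about this group; this pair shows that the two cyanophenyl groups cannot be told apart on this read-out. With 4-ethylpiperazin-1-yl on the chain, this position therefore accepts either cyanophenyl group without a change beyond the scatter.

On these data alone, whether a different group on this nitrogen, such as unsubstituted phenyl or 3-chlorophenyl, would shift the number remains open, as does whether the same exchange reads alike with benzyl(methyl)amino on the chain. The full size of the chain step also stays open because compound 1 reads only as a limit: the limit of > 100000 nM in this assay, at which 1 of the 3 values shown sits.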